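The source may hold more compounds than are shown below. What is called first, only, known or untested is meant among the compounds shown, and "the series" means these compounds.

Compound 3 `CC1CCN(c2nc(C(F)(F)F)ccc2CNC(=O)Nc2ccc3cnncc3c2)CC1` gives 8.9 nM in an assay on isolated protein for antagonist activity at transient receptor potential cation channel subfamily V member 1 (Homo sapiens), read by FLIPR; a lower number here means a stronger inhibitor, a higher number a weaker inhibitor. Compound 2 `CC1CCN(c2nc(C(F)(F)F)ccc2CNC(=O)Nc2cnc3ccccc3c2)CC1` gives 9.5 nM, and compound 1 `CC(C)(C)c1ccc(CNC(=O)Nc2cccc3cnccc23)cc1`, which carries a different left-hand portion on the urea, gives 13.8 nM; all three values lie within the scatter of one another. Within the data shown here, the one measured step that exchanges the bicyclic group on the amide-type nitrogen is a 1.1-fold lower number from compound 2 to compound 3 (0.03 log units; within the scatter), a flat step. Compound 4 `CC1CCN(c2nc(C(F)(F)F)ccc2CNC(=O)Nc2cccc3ncccc23)CC1` differs from compound 3 by a group of 10 heavy atoms (9 carbon, 1 nitrogen; one six-membered aromatic ring of carbon only, one six-membered aromatic ring with 1 hetero atom) in place of a group of 10 heavy atoms (8 carbon, 2 nitrogen; one six-membered aromatic ring of carbon only, one six-membered aromatic ring with 2 hetero atoms), on an amide-type nitrogen. Given that flat step and the narrow spread of the three compounds in this assay, no movement beyond the scatter is expected for compound 4. The expected step is therefore a 1.1-fold higher number from compound 3 to compound 4 (0.05 log units; within the scatter), nothing beyond the scatter. Compound 4 is estimated at 10 nM, with a range of 4 nM to 25 nM.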

Compound 4, inhibition constant: 0.7 nM
Estimate against measurement, compound 4: 14-fold (1.15 log units) above; the whole stated range lies above it.
By their numbers in this assay, from the lowest: compound 4; then compounds 3, 2 and 1 (each within the scatter of the next).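

In this assay, quinolin-5-yl in place of quinolin-3-yl on the amide-type nitrogen gives a 14-fold lower number from compound 2 to compound 4 (1.13 log units; beyond the scatter), and quinolin-5-yl in place of the bicyclic group with 2 nitrogen atoms gives a 13-fold lower number from compound 3 to compound 4 (1.10 log units; beyond the scatter). This position therefore responds strongly to the bicyclic group it carries, although a 1.1-fold lower number from compound 2 to compound 3 (0.03 log units; within the scatter) was flat. Nothing shown gives a reason for this gain.

Still open, as far as these compounds go, is whether naphthalen-1-yl, which has no ring nitrogen, would keep the value of compound 4 0.7 nM. Also open, from the compounds shown here alone, is how quinolin-8-yl would compare on the same core.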